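A Second Methyl on the Ester Carbon

This account rests on a few compounds, and the source may have more. Where it says the series, first, only, none or still open, it means among the compounds named here.

Compound 3 `CC1=C(C(=O)OC(C)C)C(c2cccs2)NC(=O)N1C` stands second of the three compounds measured in an assay on membranes from HeLa cells for displacement of a labelled ligand from adenosine receptor A3 (Homo sapiens), read by scintillation counting, with a stated time of 180 min, tested at 1 uM; on this read-out lower numbers stand for less inhibition and higher numbers for more inhibition at the one concentration tested (going by the name of the read-out): compound 3 gives 17%, while compound 2 `CCOC(=O)C1=C(C)N(C)C(=O)NC1c1cccs1` gives 2% and compound 1 `CC1=C(C(=O)OC(C)(C)C)C(c2ccco2)NC(=O)N1C` gives 54%. For the measured compounds named here, the only change between measured compounds here is the one from compound 2 to compound 3, methyl in place of hydrogen on a saturated chain carbon bound to an oxygen next to a carbonyl group and a saturated chain carbon, which gave a number 15 percentage points higher from compound 2 to compound 3 (beyond the scatter). Compound 4 `CC1=C(C(=O)OC(C)(C)C)C(c2cccs2)NC(=O)N1C` carries the same kind of change one stage further: methyl in place of hydrogen on a saturated chain carbon bound to an oxygen next to a carbonyl group and two saturated chain carbons. Compound 1 shares this ester group with compound 4 but differs in its ring, so its value can only hint that such an ester is compatible with a high reading. On the strength of the step from compound 2 to compound 3, compound 4 is expected to show a modest rise, a number 16 percentage points higher from compound 3 to compound 4 (beyond the scatter). The estimate for compound 4 in this assay is therefore 33%, within 15% to 58%.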

Compound 4, a percentage reported as inhibition, at one concentration (the size of the read-out at that concentration, not a potency): 22%
Compound 4: middle estimate off by 11 percentage points, on the high side, within the range that was stated.
By their numbers in this assay, from the lowest: compound 2; then compounds 3 and 4 (each within the scatter of the next); then compound 1.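

In this assay, the second methyl on this carbon, isopropyl to tert-butyl, gave a number 5 percentage points higher from compound 3 to compound 4 (within the scatter), so the gain seen with the first methyl was not extended by a step that can be read, although tert-butyl in place of ethyl on the oxygen still amounts to a number 20 percentage points higher from compound 2 to compound 4 (beyond the scatter). With the tert-butoxycarbonyl group held fixed, thiophen-2-yl in place of furan-2-yl on a saturated ring carbon gave a number 32 percentage points lower from compound 1 to compound 4 (beyond the scatter), which shows that the high reading of the furan-2-yl compound goes with that ring and not with the ester alone. No measurement available here explains either step.

As far as these compounds go, whether the ester steps would run the same way with furan-2-yl on the ring carbon remains open. So does the reading with a longer chain or benzyl on the oxygen, or with a carboxylic acid in place of the ester.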